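Replacing 3-acetylphenyl with 4-chlorophenyl on a double-bonded nitrogen

The source may report more compounds than this note shows. Statements on the series, on what has been measured and on what is new or still open speak of the compounds shown alone.

In a functional assay on HepG2 cells (Homo sapiens) for cytotoxicity, read by sulforhodamine B assay, with a stated time of 24 h (a higher number here means a weaker inhibitor, a lower number a stronger inhibitor), compound 1 `N#CCC(=O)N/N=C1\C(=O)Nc2ccc(S(=O)(=O)N3CCOCC3)cc21` gives 7530 nM and compound 2 `CC(=O)c1cccc(/N=C2\C(=O)Nc3ccc(S(=O)(=O)N4CCOCC4)cc32)c1` gives 28600 nM. Compound 2 therefore has the higher of the two numbers, making it the weaker inhibitor of this pair. Compound 3 `O=C1Nc2ccc(S(=O)(=O)N3CCOCC3)cc2/C1=N/c1ccc(Cl)cc1` keeps the shared core and has 4-chlorophenyl in place of 3-acetylphenyl on a double-bonded nitrogen. Among the measured compounds shown here, only one measured step bears on this change, a swap on that nitrogen: a 3.8-fold higher number from compound 1 to compound 2 (0.58 log units; beyond the scatter). That modest step brought in 3-acetylphenyl in place of ((cyanomethyl)carbonyl)amino. For the measured compounds named here, no measured compound carries 4-chlorophenyl, so the data offer no direction. The group that leaves and the group that enters each hold one six-membered aromatic ring of carbon only, so no change beyond the scatter is expected in this assay. The expected step is a 1.3-fold lower number from compound 2 to compound 3 (0.11 log units; within the scatter). The estimate for compound 3 is 22000 nM, within an expected range of 8000 nM to 60000 nM.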

Compound 3, half-maximal inhibitory concentration: 11800 nM
Compound 3: middle estimate off by 1.9-fold (0.27 log units), on the high side; measured number inside the range.
By their numbers in this assay, from the lowest: compounds 1 and 3 (each within the scatter of the next); then compound 2.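

Measured by this assay the change gives a 2.4-fold lower number from compound 2 to compound 3 (0.38 log units; beyond the scatter) even though the group that leaves and the group that enters each hold one six-membered aromatic ring of carbon only, so that shared ring does not alone fix the number at this nitrogen. The other new step is a 1.6-fold higher number from compound 1 to compound 3 (0.20 log units; within the scatter) and does not separate 4-chlorophenyl from ((cyanomethyl)carbonyl)amino, so an aromatic ring here does not by itself give a number higher than that of compound 1. Nothing measured here offers a reason for the gap between 3-acetylphenyl and 4-chlorophenyl.

The compounds shown leave open whether that gap follows the group on the ring or its place, which 4-acetylphenyl or 3-chlorophenyl could help to settle. Going by these compounds, how a ring carrying an amine or a carboxylic acid would behave on this nitrogen also remains open.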